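Dimethylamino in place of bromo on compound 2

The source may hold more compounds than are shown below. What is called first, only, known or untested is meant among the compounds shown, and "the series" means these compounds.

In an ADME assay on A549 cells (Homo sapiens) for cytotoxicity, read by resazurin assay, with a stated time of 48 h (a lower number here means that less compound is tolerated, a higher number that more compound is tolerated), compound 2 `O=C(Nc1ccc(NCc2ccc(Br)cc2)cc1Cl)c1cc(Cl)ccc1O` gives 40900 nM and compound 1 `CC(C)CNc1ccc(NC(=O)c2cc(Cl)ccc2O)c(Cl)c1` gives 60000 nM, so the two lie within the scatter of each other. Compound 3 `CN(C)c1ccc(CNc2ccc(NC(=O)c3cc(Cl)ccc3O)c(Cl)c2)cc1` carries dimethylamino in place of bromo on an aromatic carbon. For the measured compounds named here, no measured step tests this swap directly. The nearest, a 1.5-fold lower number from compound 1 to compound 2 (0.17 log units; within the scatter), brought in the whole 4-bromophenyl and stayed within the scatter, so no step beyond the scatter is expected in this assay. The expected change is a 1.4-fold lower number from compound 2 to compound 3 (0.13 log units; within the scatter). For compound 3 the estimate is 30000 nM, with an expected range of 12000 nM to 70000 nM.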

Compound 3, half-maximal cytotoxic concentration: 24500 nM
For compound 3 the middle estimate is 1.2-fold (0.09 log units) above the measured one; the range from low to high includes it.
By their numbers in this assay, from the lowest: compounds 3, 2 and 1 (each within the scatter of the next, the first and the last beyond it).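

In this assay, dimethylamino in place of bromo on this aromatic carbon, para to a large group, gives a 1.7-fold lower number from compound 2 to compound 3 (0.22 log units; within the scatter), so this position accepts a larger nitrogen group without a change beyond the scatter. For the compounds shown here, the whole 4-(dimethylamino)phenyl in place of isopropyl gives a 2.4-fold lower number from compound 1 to compound 3 (0.39 log units; beyond the scatter), the first step here beyond the scatter, though a modest one. Nothing available explains either step. The compounds shown leave open how a carboxylic acid or a methoxy group at this same position would read in this assay.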